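Swapping Two Halogens on a Well-Tolerated Compound

The source may hold more compounds than are shown below. What is called first, only, known or untested is meant among the compounds shown, and "the series" means these compounds.

In an ADME assay on MT2 cells (Homo sapiens) for cytotoxicity, read by XTT assay, with a stated time of 4 days (a higher number here means that more compound is tolerated, a lower number that less compound is tolerated), compound 1 `Cc1ccc(NC(=O)C(=O)NC(c2nc(C)c(CCO)s2)C2CCCCN2)cc1F` gives 85000 nM. Compound 2 `Cc1nc(C(NC(=O)C(=O)Nc2ccc(F)c(Cl)c2)C2CCCCN2)sc1CO` gives > 77800 nM, which is a limit of the assay and not a number. Compound 3 `Cc1nc(C(NC(=O)C(=O)Nc2ccc(Cl)c(F)c2)C2CCCCN2)sc1CO` has the same atoms as compound 2, joined differently: 4-chloro-3-fluorophenyl in place of 3-chloro-4-fluorophenyl on an amide-type nitrogen, with 4-chloro-3-fluorophenyl in place of 3-chloro-4-fluorophenyl on an amide-type nitrogen. For the measured compounds named here, no measured pair shows this kind of change. No step beyond the scatter is expected in this assay, in either direction. The estimated step that the limit leaves unreadable from compound 2 to compound 3 is small. For compound 3 the expected value is 85000 nM, with a range from 45000 nM to 160000 nM.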

Compound 3, half-maximal cytotoxic concentration: 77800 nM
The estimate for compound 3 lay 1.1-fold (0.04 log units) above the measured number; low and high end bracket the measured number.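

With 4-chloro-3-fluorophenyl in place of 3-chloro-4-fluorophenyl on the amide-type nitrogen, the data give a number no higher from compound 2 to compound 3 (the limit leaves the size open). Compound 3 gives a measured number, whereas compound 2 gave only a limit of the assay. The size of the step between them cannot be read because of that limit: the limit of > 77800 nM in this assay, at which 1 of the 3 values shown sits. Moving the two halogens therefore has no measurable size here, and the data cannot say whether the swap matters at all. Still open, from the compounds shown here alone, is how tolerance would respond if an amine or a carboxylic acid replaced a halogen on this ring.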